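The source may hold more compounds than are shown below. What is called first, only, known or untested is meant among the compounds shown, and "the series" means these compounds.

Measured in an ADME assay on S9 fraction from liver (Rattus norvegicus, strain Sprague-Dawley) for metabolic stability, read by LC-MS, using NADPH, with stated times of 5 min and 60 min, tested at 5 uM; on this read-out higher numbers stand for a more stable compound and lower numbers for a less stable compound:
- compound 1 `COc1cc(C2CN(C(=O)c3cc(OCCO)ccn3)C2)ccc1OCc1ccc(C2CC2)cc1`: 51%
- compound 2 `COc1ccc(COc2ccc(C3CN(C(=O)c4cc(OCCO)ccn4)C3)cc2OC)cc1`: 49%

Compound 1, at 51%, stands level with compound 2 once the scatter is allowed for. Among the measured compounds shown here, the only measured step is a number 2 percentage points lower from compound 1 to compound 2 (within the scatter), and it comes from methoxy in place of cyclopropyl on an aromatic carbon.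

Compound 3 `COc1cc(C2CN(C(=O)c3cc(OC[C@H](O)CO)ccn3)C2)ccc1OCc1ccc(C2CC2)cc1` keeps the cyclopropyl of compound 1 and changes the other end of the molecule: hydroxymethyl in place of hydrogen on a saturated chain carbon bound to an oxygen on a saturated carbon and a saturated chain carbon. Cut one bond further out, the same difference reads 2-hydroxyethoxy to 2,3-dihydroxypropoxy.

For the measured compounds named here, no step at this place has been measured, so the evidence is indirect. The step to compound 2 involves a different group and bears on the new change only loosely. It shows that one substitution on this scaffold can leave the reading in this assay within the scatter, as a number 2 percentage points lower from compound 1 to compound 2 (within the scatter) shows. No shift beyond the scatter is therefore expected, in either direction, though the range has to stay wide.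

The expected step is a number 2 percentage points higher from compound 1 to compound 3 (within the scatter). For compound 3 the estimated value is 53%, with an expected range of 40% to 66%.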

Compound 3, percent of the compound remaining: 67%
The estimate for compound 3 lay 14 percentage points below the measured number, outside the stated range (above it).
By their numbers in this assay, from the lowest: compounds 2 and 1 (each within the scatter of the next); then compound 3.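

In this assay, going from 2-hydroxyethoxy to 2,3-dihydroxypropoxy gives a number 16 percentage points higher from compound 1 to compound 3 (beyond the scatter), so one added hydroxymethyl on this saturated chain carbon moves the number towards a more stable compound. Among the compounds shown here, the earlier change at the other end of the molecule gave only a number 2 percentage points lower from compound 1 to compound 2 (within the scatter), which means that this chain is the first place where a single substitution moves the read-out beyond the scatter. No available data bear on the reason for this rise.

On these data alone, it remains open whether the rise depends on the hydroxymethyl itself, or whether an aminomethyl, a carboxylic acid or a longer chain such as 3,4-dihydroxybutoxy on the same carbon would give a similar number, and whether the opposite configuration at that carbon would read the same. As far as these compounds go, it is also open whether 2,3-dihydroxypropoxy would give a similar step in the methoxy partner, compound 2, or whether the step seen here holds only with cyclopropyl at the far end of the molecule.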